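The source may report more compounds than this note shows. Statements on the series, on what has been measured and on what is new or still open speak of the compounds shown alone.

Compound 3 `COc1ccc(Cc2nnc3n2NC(c2ccco2)S3)cc1OC` gives 21.1% in a functional assay on the whole organism (strain Wistar Albino) for inhibition, with Rattus norvegicus as the target, read by paw edema, with a stated time of 3 h, at a dose of 20 mg/kg (on this read-out higher numbers stand for more inhibition at the one dose given (going by the name of the read-out) and lower numbers for less inhibition), the highest of the three numbers measured, though both others lie within the scatter of it. Among the compounds with values here, compound 2 `Cc1occc1-c1nnc2sc(-c3ccnc4ccccc34)nn12` gives 20.3% and compound 1 `Cc1cc(-c2nn3c(-c4ccoc4C)nnc3s2)c2ccccc2n1` gives 18.6%; the single measured step, hydrogen in place of methyl on an aromatic carbon, runs a number 1.7 percentage points higher from compound 1 to compound 2 (within the scatter). Compound 4 `COc1ccc(Cc2nnc3n2NC(c2ccc([N+](=O)[O-])o2)S3)cc1OC` differs from compound 3 by nitro in place of hydrogen on an aromatic carbon. Within the data shown here, no measured step bears on this change: the one step known sits on a different core and swaps a methyl, not a nitro. The step is therefore expected to be a number 0.9 percentage points higher from compound 3 to compound 4 (within the scatter), with no movement beyond the scatter. Compound 4 is estimated to give 22%, in a range from 12% to 32%.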

Compound 4, a percentage reported as inhibition, in the whole organism at one dose (the size of the read-out at that dose, not a potency): 21.4%
For compound 4 the middle estimate is 0.6 percentage points above the measured one; low and high end bracket the measured number.
By their numbers in this assay, from the lowest: compounds 1, 2, 3 and 4 (each within the scatter of the next).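

In this assay, going from furan-2-yl to 5-nitrofuran-2-yl gives a number 0.3 percentage points higher from compound 3 to compound 4 (within the scatter), so this carbon next to the ring oxygen carries nitro, with its 3 heavy atoms, without a shift beyond the scatter. This is the only step shown on the core of compound 3, as the earlier step swapped a methyl on a different core. No available evidence bears on why the step is this small.

From the compounds shown here alone, whether an amine or a carboxylic acid at this carbon would read differently remains open. So does whether nitro would behave alike on the core of compound 1.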